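Methylating the Ring Amide Nitrogen of Compound 1

A few compounds are considered here, and "the series" means these few. Any claim that something is new, unique, unknown or untested is made for them only; others in the source may bear on it.

Compound 1 `NS(=O)(=O)c1ccc(/N=C2\NC(=O)/C(=C3/C(=O)Nc4ccccc43)S2)cc1` was tested in a functional assay on Caco-2 cells (Homo sapiens) for antiproliferative activity, read by MTT assay; a lower number here means a stronger inhibitor, a higher number a weaker inhibitor. In that test compound 1 gives only a limit, > 200000 nM, so its true number is not known. Its place among the values shown is the limit of > 200000 nM in this assay, at which 1 of the 3 values shown sits.

Two related compounds carry a substituent on an aromatic carbon of the shared core. Compound 2 `NS(=O)(=O)c1ccc(/N=C2\NC(=O)/C(=C3/C(=O)Nc4ccc(Br)cc43)S2)cc1` gives 42300 nM in this assay, and compound 3 `NS(=O)(=O)c1ccc(/N=C2\NC(=O)/C(=C3/C(=O)Nc4ccc([N+](=O)[O-])cc43)S2)cc1` gives 13800 nM. The measured steps are an at least 4.7-fold lower number from compound 1 to compound 2 (0.67 log units; beyond the scatter), an at least 14-fold lower number from compound 1 to compound 3 (1.16 log units; beyond the scatter) and a 3.1-fold lower number from compound 2 to compound 3 (0.49 log units; beyond the scatter).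

Compound 4 `CN1C(=O)/C(=C2\S/C(=N/c3ccc(S(N)(=O)=O)cc3)NC2=O)c2ccccc21` differs from compound 1 in another place: methyl in place of hydrogen on an amide-type nitrogen in a ring. Every measured step alters an aromatic carbon; none touches this nitrogen, so none of them bears on the change, and no step beyond the scatter is expected. Compound 1 itself stands at a limit. Compound 4 is expected to give 250000 nM, within 80000 nM to 800000 nM, most likely again reported only as a limit. The expected step is a step that the limit leaves unreadable from compound 1 to compound 4.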

Compound 4, half-maximal inhibitory concentration: 163000 nM
For compound 4 the middle estimate is 1.5-fold (0.19 log units) above the measured one; the measured number falls inside the stated range.
By their numbers in this assay, from the lowest: compound 3; then compound 2; then compound 4. At a limit, above all of these: compound 1.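

Compound 4 alone among the compounds shown carries a change on the amide-type nitrogen in a ring, and with methyl there this assay returns a number rather than a limit. The change gives an at least 1.2-fold lower number from compound 1 to compound 4 (0.08 log units; that floor lies within the scatter), so this floor shows no clear effect of methyl in place of hydrogen, although the true step could be larger. Compound 1 remains a limit, not a number, so the size of the step stays unknown: the limit of > 200000 nM in this assay, at which 1 of the 4 values shown sits.

On these data alone, whether a longer chain such as ethyl or propyl, or a benzyl group, on this nitrogen would give a number close to that of compound 4 remains open. Also open, as far as these compounds go, is whether methyl on this nitrogen would change the number of compound 2 or compound 3, which carry bromo and nitro on an aromatic carbon.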